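Dithiocarbamate series: aryl for cyclohexyl on the piperazine nitrogen

A few compounds are considered here, and "the series" means these few. Any claim that something is new, unique, unknown or untested is made for them only; others in the source may bear on it.

Compound 1 `Nc1nc(N)c2cc(CSC(=S)N3CCN(C4CCCCC4)CC3)ccc2n1` is the reference point. Within the data shown here, in a functional assay on HT-29 cells (Homo sapiens) for antiproliferative activity, read by MTT assay, with a stated time of 72 h (a higher number here means a weaker inhibitor, a lower number a stronger inhibitor), compound 1 gives 4050 nM, the highest of the two numbers so far; the nearest is compound 2 `Cc1ccc(N2CCN(C(=S)SCc3ccc4nc(N)nc(N)c4c3)CC2)cc1`, which in this assay gives 3020 nM. Among the measured compounds shown here, the only measured step, a 1.3-fold lower number from compound 1 to compound 2 (0.13 log units; within the scatter), comes from putting 4-methylphenyl in place of cyclohexyl on an amine nitrogen in a ring, and it lies within the scatter.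

Compound 3 `Nc1nc(N)c2cc(CSC(=S)N3CCN(c4ccc(F)cc4)CC3)ccc2n1` is not yet measured. It differs from compound 1 in one place: 4-fluorophenyl in place of cyclohexyl on an amine nitrogen in a ring. For the measured compounds named here, the one step that bears on this, a 1.3-fold lower number from compound 1 to compound 2 (0.13 log units; within the scatter), exchanges the same cyclohexyl for another six-membered aromatic ring of carbon only at the same position, so an aromatic ring on that nitrogen has so far left the number essentially unchanged. Going by the values given here, no step separates 4-fluorophenyl from 4-methylphenyl at this site, so nothing further can be read from the data.

The expectation for compound 3 in this assay is therefore a step of a 1.3-fold lower number from compound 1 to compound 3 (0.10 log units; within the scatter), not beyond the scatter. Compound 3 is estimated at 3200 nM, with a range from 1600 nM to 6400 nM.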

Compound 3, half-maximal inhibitory concentration: 2050 nM
The estimate for compound 3 lay 1.6-fold (0.19 log units) above the measured number; low and high end bracket the measured number.
By their numbers in this assay, from the lowest: compounds 3, 2 and 1 (each within the scatter of the next).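

On the amine nitrogen in the ring, a second aromatic group now stands in place of cyclohexyl: in this assay 4-fluorophenyl gives a 2.0-fold lower number from compound 1 to compound 3 (0.30 log units; within the scatter) and sits at the edge of the scatter without passing it, so compound 2 and compound 3 both remain within the scatter of compound 1. The first comparison made on the aromatic ring itself, fluoro in place of methyl on an aromatic carbon, gives a 1.5-fold lower number from compound 2 to compound 3 (0.17 log units; within the scatter) and so does not separate the two compounds. Across cyclohexyl, 4-methylphenyl and 4-fluorophenyl, this position has therefore shown no step beyond the scatter in this assay, and the three compounds stand as one group of equal numbers.

Still open, from the compounds shown here alone, is whether a group of another kind on this nitrogen, such as a longer alkyl chain, or an amine or a carboxylic acid on the aromatic ring, would give a step beyond the scatter. What lies behind these numbers also stays open, as nothing measured bears on it.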